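The source may report more compounds than this note shows. Statements on the series, on what has been measured and on what is new or still open speak of the compounds shown alone.

Measured so far in a functional assay on NCI-H460 cells (Homo sapiens) for antiproliferative activity, read by MTT assay, with a stated time of 48 h; on this read-out lower numbers stand for stronger inhibition and higher numbers for weaker inhibition:
compound 1, `COc1cccc(-c2nc3cccc(-c4cc(OC)c(OC)c(OC)c4)c3o2)c1`: > 25000 nM
compound 2, `COc1ccc(-c2nc3cccc(-c4cc(OC)c(OC)c(OC)c4)c3o2)cc1F`: 2800 nM
compound 3, `COc1cc(-c2cccc3nc(-c4ccc(F)cc4)oc23)cc(OC)c1OC`: 8700 nM

Compound 1 stands at the limit of > 25000 nM in this assay, at which 1 of the 3 values shown sits, so for compound 1 only a limit is known and not a number. Compound 2 and compound 3 both give numbers within the range of this assay.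

Compound 4, `COc1cc(-c2cccc3nc(-c4ccc(Cl)cc4)oc23)cc(OC)c1OC`, is not yet measured. It differs from compound 1 by 4-chlorophenyl in place of 3-methoxyphenyl on an aromatic carbon. Two measured steps start from the same compound 1 and change the same group: an at least 8.9-fold lower number from compound 1 to compound 2 (0.95 log units; beyond the scatter) and an at least 2.8-fold lower number from compound 1 to compound 3 (0.45 log units; beyond the scatter). Between those two end points, a 3.1-fold higher number from compound 2 to compound 3 (0.49 log units; beyond the scatter). Going by the values given here, of the three measured compounds, compound 3 with its 4-fluorophenyl is the closest precedent for the 4-chlorophenyl of compound 4, so a step of roughly the size seen from compound 1 to compound 3 is expected, in the direction of a lower number, beyond the scatter, with compound 2 showing that the swap away from 3-methoxyphenyl can reach further still.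

For compound 4 in this assay the expected value is 7000 nM, with a range from 2500 nM to 20000 nM. The step this estimate implies, an at least 3.5-fold lower number from compound 1 to compound 4 (0.55 log units; beyond the scatter), is expected to take compound 4 clear of the limit at which compound 1 sits.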

Compound 4, half-maximal inhibitory concentration: > 25000 nM
Compound 4 was reported as a limit (the forecaster's own chance of this, stated with the estimate: 10%); middle value at least 3.5-fold (0.55 log units) from the limit.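

In this assay, the position on the five-membered aromatic ring, next to the ring nitrogen and next to the ring oxygen, proves sensitive to a single atom on the attached phenyl: chloro in place of fluoro gives an at least 2.8-fold higher number from compound 3 to compound 4 (0.45 log units; beyond the scatter). The earlier compounds shown here showed only exchanges of whole substituted phenyl groups, and compound 3 had suggested that a 4-halophenyl might be enough to give a measurable number, yet compound 4 does not share this, and the wider gap is an at least 8.9-fold higher number from compound 2 to compound 4 (0.95 log units; beyond the scatter). Compound 4 is reported only as a limit, as is compound 1, so the step between them cannot be read and 4-chlorophenyl and 3-methoxyphenyl cannot be ordered: the limit of > 25000 nM in this assay, at which 2 of the 4 values shown sit.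

The compounds shown leave open whether a 4-bromophenyl or a plain phenyl at this position would fall with compound 3 or with compound 4. They also leave open which part of the 3-fluoro-4-methoxyphenyl of compound 2 goes with its lower number, a question that a 4-methoxyphenyl at the same position would help to separate.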